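The compounds below may be only part of what the source reports. "The series", "measured", "known", "first", "only" and "open" are said of these compounds alone.

Measured compounds in a functional assay on CFPAC-1 cells (Homo sapiens) for antiproliferative activity, read by MTT assay, with a stated time of 72 h; on this read-out higher numbers stand for weaker inhibition and lower numbers for stronger inhibition:
Compound 1 `CC(C)(C)c1cn(C[C@H](O)[C@H]2OC(=O)C(OCc3ccccc3)=C2OCc2ccccc2)nn1` gives 54900 nM.
Compound 2 `O=C1O[C@H]([C@@H](O)Cn2cc(-c3cc(F)cc(F)c3)nn2)C(OCc2ccccc2)=C1OCc1ccccc1` gives 62400 nM.
Compound 3 `Cc1ccc(-c2cn(C/C=C3\OC(=O)C(OCc4ccccc4)=C3OCc3ccccc3)nn2)cc1` gives only a limit of the assay, > 100000 nM, not a number.

Among the measured compounds shown here, compound 3 thus stands at the limit of this assay, so no step from compound 1 or compound 2 to it can be sized. Compound 4 `COc1ccccc1-c1cn(C/C=C2\OC(=O)C(OCc3ccccc3)=C2OCc2ccccc2)nn1` differs from compound 3 by 2-methoxyphenyl in place of 4-methylphenyl on an aromatic carbon. For the measured compounds named here, no measured step touches this pair directly; the only measured step, a 1.1-fold higher number from compound 1 to compound 2 (0.06 log units; within the scatter), swapped a different group on the same kind of aromatic carbon and stayed within the scatter, while the limit of > 100000 nM in this assay, at which 1 of the 3 values shown sits, marks how weak compound 3 is. For compound 4 no step beyond the scatter is expected, a number no higher from compound 3 to compound 4 (the limit leaves the size open). Compound 4 is therefore estimated at 100000 nM, between 40000 nM and 250000 nM, with a real chance that this assay again reports only a limit.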

Compound 4, half-maximal inhibitory concentration: > 100000 nM
Compound 4: a limit, no number; the forecaster's own chance of this, stated with the estimate: 60%; the middle value lies on the limit itself.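

Among the compounds shown here, compound 3 and compound 4 both give only a limit in this assay, not a number, so no step between them can be read. On these data alone, whether 2-methoxyphenyl and 4-methylphenyl differ on this read-out stays open.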